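This account rests on a few compounds, and the source may have more. Where it says the series, first, only, none or still open, it means among the compounds named here.

Measured in a functional assay on MCF7 cells (Homo sapiens) for antiproliferative activity, read by MTT assay, with a stated time of 72 h; a lower number here means a stronger inhibitor, a higher number a weaker inhibitor:
- compound 1 `CC1=CC[C@H]2[C@H](CC[C@]2(C)O)C(C)(C)[C@@H]1CC[C@H]1[C@]2(C)CC[C@H](OC(=O)CCC(=O)O)C(C)(C)O[C@H]2CC[C@@]1(C)O`: > 50000 nM
- compound 2 `CC(=O)O[C@H]1CC[C@]2(C)[C@H](CC[C@@](C)(O)[C@H]2CC[C@@H]2C(C)=CC[C@@H]3C(C)=CC[C@@H]3C2(C)C)OC1(C)C`: 43500 nM
- compound 3 `CC1=CC[C@H]2[C@@H]1CC=C(C)[C@@H](CC[C@H]1[C@]3(C)CC[C@H](OC(=O)c4ccncc4)C(C)(C)O[C@H]3CC[C@@]1(C)O)C2(C)C`: > 50000 nM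

Not yet measured: compound 4 `CC1=CC[C@H]2[C@H](CC[C@]2(C)O)C(C)(C)[C@@H]1CC[C@H]1[C@]2(C)CC[C@H](OCc3ccccc3)C(C)(C)O[C@H]2CC[C@@]1(C)O`.

Compound 1 gives > 50000 nM, which is a limit and not a number. Compound 3 also gives > 50000 nM, again a limit only. Among the measured compounds shown here, compound 2 gives 43500 nM, the only true number in the set. The overall picture is the limit of > 50000 nM in this assay, at which 2 of the 3 values shown sit. The position of compound 1 is therefore known only as a limit, and no size of step can be read from it.

The change under consideration is benzyl in place of (2-carboxyethyl)carbonyl on an oxygen on a saturated carbon. In short, it is benzyl in place of (2-carboxyethyl)carbonyl on an oxygen on a saturated carbon. For the measured compounds named here, no measured step covers this change. Going by the values given here, the only measured step is an at least 1.1-fold higher number from compound 2 to compound 3 (0.06 log units; that floor lies within the scatter), which is a replacement on a carbonyl carbon and so bears on the present change only loosely. It offers no support for a large shift in this assay. The value of compound 2 at 43500 nM suggests that a weak number of similar size is what can be expected. Among the compounds with values here, no step clearly beyond the scatter is expected, and the estimated step is an at least 1.2-fold lower number from compound 1 to compound 4 (0.09 log units; that floor lies within the scatter). For compound 4 the expected value is 40000 nM, with an estimated range from 15000 nM to 50000 nM.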

Compound 4, half-maximal inhibitory concentration: > 50000 nM
Compound 4 was reported as a limit (the forecaster's own chance of this, stated with the estimate: 45%); at least 1.2-fold (0.09 log units) between middle value and limit.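

In this assay compound 4 gives a limit, > 50000 nM. Compound 1 also gives a limit, > 50000 nM. Among the compounds shown here, no step between compound 1 and compound 4 can be read. The compounds shown leave open how benzyl and (2-carboxyethyl)carbonyl compare on this oxygen, and the series stands mostly at a single value: the limit of > 50000 nM in this assay, at which 3 of the 4 values shown sit.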